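A trifluoromethoxy swap on compound 3

The source may hold more compounds than are shown below. What is called first, only, known or untested is meant among the compounds shown, and "the series" means these compounds.

In a functional assay on LNCaP cells (Homo sapiens) for antiproliferative activity, read by propidium iodide staining, with a stated time of 96 h (on this read-out higher numbers stand for weaker inhibition and lower numbers for stronger inhibition), compound 1 `CC(O)(CSc1cccc(S(F)(F)(F)(F)F)c1)C(=O)Nc1ccc(C#N)cc1C(F)(F)F` gives 17600 nM, compound 2 `CC(O)(CSc1ccc(S(F)(F)(F)(F)F)cc1)C(=O)Nc1ccc(S(F)(F)(F)(F)F)cc1` gives 18300 nM and compound 3 `CC(O)(CSc1cccc(S(F)(F)(F)(F)F)c1)C(=O)Nc1cccc(S(F)(F)(F)(F)F)c1` gives 12900 nM. Compound 3 stands within the scatter of both other compounds, so the three cannot be ranked. Compound 4 `CC(O)(CSc1cccc(OC(F)(F)F)c1)C(=O)Nc1cccc(S(F)(F)(F)(F)F)c1` differs from compound 3 in one place, (a group of 5 heavy atoms (1 carbon, 1 oxygen, 3 fluorine; no ring) in place of a group of 6 heavy atoms (5 fluorine, 1 sulfur; no ring), on an aromatic carbon), on an aromatic carbon, meta to a large group. For the measured compounds named here, no measured pair shows this change on its own, so its size can only be judged from the narrow spread of the three values, with compound 3 at 12900 nM. The step expected in this assay is none beyond the scatter, a 1.2-fold higher number from compound 3 to compound 4 (0.07 log units; within the scatter). Compound 4 is estimated at 15000 nM, with an expected range from 7000 nM to 30000 nM.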

Compound 4, half-maximal inhibitory concentration: 10900 nM
Estimate against measurement, compound 4: 1.4-fold (0.14 log units) above; low and high end bracket the measured number.
By their numbers in this assay, from the lowest: compounds 4, 3, 1 and 2 (each within the scatter of the next).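

In this assay, trifluoromethoxy in place of the five-fluorine sulfur group on this aromatic carbon gives a 1.2-fold lower number from compound 3 to compound 4 (0.07 log units; within the scatter) and so leaves the read-out unchanged. For the compounds shown here, this is the first comparison in the set that isolates a single change, and it shows that this position accepts either group with no readable effect. Nothing measured here offers an explanation for this result.

From the compounds shown here alone, whether an amine or a carboxylic acid on this carbon would move the number beyond the scatter remains open. So does whether the same swap would behave alike with nitrile and trifluoromethyl on the other ring.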